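The source may hold more compounds than are shown below. What is called first, only, known or untested is meant among the compounds shown, and "the series" means these compounds.

In a functional assay on cells (Homo sapiens) for cytotoxicity, read by MTT assay, with a stated time of 24 h (on this read-out higher numbers stand for weaker inhibition and lower numbers for stronger inhibition), compound 1 (`CCCCCCCCCCCCCCNC(=O)[C@H](CO)/N=C/c1ccccc1OC`) gives 12500 nM and compound 2 (`CCCCCCCCCCCCCCNC(=O)[C@H](CO)/N=C/c1ccccc1`) gives 7670 nM while compound 3 (`CCCCCCCCCCCCCCNC(=O)[C@H](CO)/N=C/c1ccc([N+](=O)[O-])cc1`) stands highest of the three at 217000 nM on this scale. Compound 4 (`CCCCCCCCCCCCCCNC(=O)[C@H](CO)/N=C/c1cccc(O)c1`) is still unmeasured. It has 3-hydroxyphenyl in place of 4-nitrophenyl on a carbon with a double bond to nitrogen. Only compound 3 carries the 4-nitrophenyl group, and the steps into it were large (a 17-fold higher number from compound 1 to compound 3 (1.24 log units; beyond the scatter)) and (a 28-fold higher number from compound 2 to compound 3 (1.45 log units; beyond the scatter)). The step between the other two was small (a 1.6-fold lower number from compound 1 to compound 2 (0.21 log units; within the scatter)). For the measured compounds named here, no compound with a 3-hydroxyphenyl group has been measured yet, but a large drop in the number is expected in this assay (a 22-fold lower number from compound 3 to compound 4 (1.34 log units; beyond the scatter)). For compound 4 the estimate is 10000 nM with 3500 nM to 30000 nM as its expected range.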

Compound 4, half-maximal inhibitory concentration: 32600 nM
Estimate against measurement, compound 4: 3.3-fold (0.51 log units) below; measured number outside the range, above it.
By their numbers in this assay, from the lowest: compounds 2 and 1 (each within the scatter of the next); then compound 4; then compound 3.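

Swapping the 4-nitrophenyl group for 3-hydroxyphenyl lowers the number in this assay (a 6.7-fold lower number from compound 3 to compound 4 (0.82 log units; beyond the scatter)), but not back to the level of the earlier compounds (a 4.3-fold higher number from compound 2 to compound 4 (0.63 log units; beyond the scatter)) (a 2.6-fold higher number from compound 1 to compound 4 (0.42 log units; beyond the scatter)). For the compounds shown here, the values at this place therefore fall into three levels rather than two, and compound 3 is no longer the only compound clearly above the unsubstituted phenyl of compound 2. No measurement shown explains these shifts. As far as these compounds go, what an amine or a carboxylic acid on the phenyl ring would do remains open. So does the effect of a longer chain on the shared core.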